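The source may report more compounds than this note shows. Statements on the series, on what has been measured and on what is new or still open speak of the compounds shown alone.

Measured compounds:
compound 1 `CCNc1ccc2c(c1)OC(N)=C(C#N)C2c1cccc([N+](=O)[O-])c1` — 110000000 nM
compound 2 `COc1cc(C2C(C#N)=C(N)Oc3cc(Br)ccc32)cc(Br)c1OC` — 140000000 nM

Both measured compounds share the same core and both sit at very high concentrations in a functional assay on T47D cells (Homo sapiens) for activation; on this read-out higher numbers stand for an effect only at larger amounts of compound and lower numbers for an effect already at smaller amounts. In this assay compound 1 gives 110000000 nM, and compound 2 gives 140000000 nM; the gap between the two falls within the usual scatter, so the two cannot be told apart, and neither can be called the more active.

Compound 3 `COc1ccc2c(c1)OC(N)=C(C#N)C2c1cccc([N+](=O)[O-])c1` has not been measured. It differs from compound 1 by methoxy in place of ethylamino on an aromatic carbon. Among the compounds with values here, no measured pair shows what such a swap does on this core. With both known values lying at a similar high level, no step beyond the scatter is expected from compound 1 to compound 3; the estimated step is a 1.1-fold higher number from compound 1 to compound 3 (0.04 log units; within the scatter). Compound 3 is expected to give 120000000 nM in this assay, within a range of 40000000 nM to 400000000 nM.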

Compound 3, half-maximal effective concentration: 88900000 nM
Estimate against measurement, compound 3: 1.3-fold (0.13 log units) above, and the stated range covers the measured number.
By their numbers in this assay, from the lowest: compounds 3, 1 and 2 (each within the scatter of the next).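

Within the data shown here, the first measured pair on the shared core puts methoxy in place of ethylamino on an aromatic carbon, para to a fused ring, and in this assay it gives a 1.2-fold lower number from compound 1 to compound 3 (0.09 log units; within the scatter). The hydrogen-bond donor counted on ethylamino is absent from methoxy, yet this read-out does not separate the two compounds, so neither group can be ranked over the other at this position. Nothing available explains why the two groups read alike.

Open, from the compounds shown here alone, is whether a free amine, a carboxylic acid or a longer alkoxy chain on this aromatic carbon would shift the number beyond the scatter. Also open, going by these compounds, is whether any change on the shared core brings an effect at much smaller amounts of compound, as all three numbers lie at a similar high level.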